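Biaryl series: sulfonamide to acetamide swap at the meta position

The compounds below may be only part of what the source reports. "The series", "measured", "known", "first", "only" and "open" are said of these compounds alone.

Two members of this biaryl set carry measured values. Compound 1 `CCOC(=O)c1ccnc(-c2ccc(OCC)cc2)c1` is the reference point: in an assay on COS-7 cells for inhibition of patatin-like phospholipase domain-containing protein 2 (Mus musculus), tested at 200 uM (a higher number here means more inhibition at the concentration tested (going by the name of the read-out), a lower number less inhibition), compound 1 gives 87%. Compound 2 `CCOc1ccc(-c2cccc(S(=O)(=O)NC)c2)cc1` replaces the pyridine ester side with a benzene ring bearing a methylsulfamoyl group, and in this assay compound 2 gives 47%. Going by the values given here, of the two numbers recorded, compound 2 stands lowest; its only neighbour is compound 1, and that gap is beyond the scatter of repeated runs. The two structures differ in more than one place, so nothing can be said of which part of the change carries the drop.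

Compound 3 `CCOc1ccc(-c2cccc(NC(C)=O)c2)cc1` is not yet measured. Against compound 2 the change is acetamido in place of methylsulfamoyl on an aromatic carbon. Both the leaving and the entering group contribute one hydrogen-bond donor; the count of acceptors falls by one. Among the compounds with values here, no measured pair in the set isolates this kind of exchange, so there is no step to lean on. The expectation is a step from compound 2 to compound 3 of a number 3 percentage points higher from compound 2 to compound 3 (within the scatter), that is, nothing clearly beyond the scatter in either direction. Compound 3 is therefore estimated at 50%, with a range from 25% to 75%.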

Compound 3, a percentage reported as inhibition, at one concentration (the size of the read-out at that concentration, not a potency): 52%
For compound 3 the middle estimate is 2 percentage points below the measured one, within the range that was stated.
By their numbers in this assay, from the lowest: compounds 2 and 3 (each within the scatter of the next); then compound 1.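

In this assay, going by these compounds alone, the exchange of methylsulfamoyl for acetamido on an aromatic carbon, meta to a group of 9 heavy atoms, gives the first comparison in this set that differs in one place: a number 5 percentage points higher from compound 2 to compound 3 (within the scatter). At this place the read-out therefore does not separate the two groups, even though their counts of heavy atoms, double bonds and hydrogen-bond acceptors differ while each keeps 1 hydrogen-bond donor. There is no measurement at hand that bears on the reason for this result.

Going by these compounds, it remains open whether a carboxylic acid, an amine or a longer acyl chain on the same aromatic carbon would give a step beyond the scatter, since these two groups cover only a narrow part of what could sit there. Compound 1 differs from compound 2 and compound 3 in more than one place, so the part of its structure that accounts for its higher number also stays unresolved, and a reading at one concentration gives no potency for any of the three.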